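Thiophene regiochemistry at the amide of the acetogenin series

The source may report more compounds than this note shows. Statements on the series, on what has been measured and on what is new or still open speak of the compounds shown alone.

Measured compounds:
Compound 1 `CCCCCCCCCCCC[C@@H](O)[C@H]1CC[C@H]([C@H](O)CCCCCCCCCCNC(=O)c2cncs2)O1`, in a functional assay on OVCAR-4 cells (Homo sapiens) for inhibition, read by colorimetric assay and sulforhodamine B assay, with a stated time of 48 h (a lower number here means a stronger inhibitor of growth, a higher number a weaker inhibitor of growth), compound 1 gives 100000 nM.
Compound 2 `CCCCCCCCCCCC[C@@H](O)[C@H]1CC[C@H]([C@H](O)CCCCCCCCCCNC(=O)c2ccsc2)O1`, in this assay compound 2 gives 1700 nM.

Among the compounds with values here, compound 2 stands at the lowest number of the two measured; the only neighbour is compound 1, and the move a 59-fold lower number from compound 1 to compound 2 (1.77 log units; beyond the scatter), thiophen-3-yl in place of 1,3-thiazol-5-yl on a carbonyl carbon, is the single step recorded so far.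

Compound 3 `CCCCCCCCCCCC[C@@H](O)[C@H]1CC[C@H]([C@H](O)CCCCCCCCCCNC(=O)c2cccs2)O1` is the next member. The change is thiophen-2-yl in place of thiophen-3-yl on a carbonyl carbon. Within the data shown here, no measured step tests this particular rearrangement: the one recorded step swaps a thiazole for a thiophene, not one thiophene attachment for another, so it bears only loosely on the question and gives no direction. With the same atoms joined differently, the working expectation is a step within the scatter of this assay, a 1.1-fold lower number from compound 2 to compound 3 (0.05 log units; within the scatter), with no firm direction. Compound 3 is therefore estimated at 1500 nM, with a range from 400 nM to 6000 nM, pending the measurement.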

Compound 3, concentration for 50% growth inhibition: 1820 nM
For compound 3 the middle estimate is 1.2-fold (0.08 log units) below the measured one, within the range that was stated.
By their numbers in this assay, from the lowest: compounds 2 and 3 (each within the scatter of the next); then compound 1.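

In this assay, the point of attachment of the thiophene on the carbonyl carbon, next to the amide-type nitrogen in neither a new nor a tested sense beyond this one swap, gives no readable difference: thiophen-2-yl and thiophen-3-yl cannot be told apart at this position (a 1.1-fold higher number from compound 2 to compound 3 (0.03 log units; within the scatter)). The large step away from the 1,3-thiazol-5-yl amide also appears with the second thiophene (a 55-fold lower number from compound 1 to compound 3 (1.74 log units; beyond the scatter)), so among these three compounds it is not tied to one thiophene attachment, and compound 2 and compound 3 both stand well apart from compound 1. Nothing measured in this set accounts for the distance between the thiazole and the two thiophenes.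

Open, on these data alone, is whether a phenyl or a furan-2-yl on the same carbonyl carbon would fall with the two thiophenes or with the thiazole, and whether a 1,3-thiazol-2-yl or a 1,3-thiazol-4-yl would read like the 1,3-thiazol-5-yl of compound 1. Also open, as far as these compounds go, is how the thiophene amides would read with a shorter chain joining the amide nitrogen to the shared core.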